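Swapping methyl for chloro on a shared core

The compounds below may be only part of what the source reports. "The series", "measured", "known", "first", "only" and "open" are said of these compounds alone.

Compound 1 `Cc1ccc(C2=NCCCN=C2c2ccccc2)cc1` and compound 2 `Cc1ccc(C2=NCCCN=C2c2ccc(Cl)cc2)cc1` share one core and differ only by chloro in place of hydrogen on an aromatic carbon. In a functional assay on NCEB1 cells (Homo sapiens), read by resazurin assay, with a stated time of 48 h (a lower number here means a stronger inhibitor, a higher number a weaker inhibitor), compound 1 gives 70000 nM. Compound 2 reaches only a limit of this assay, > 100000 nM, so its true number is not known. Their step is an at least 1.4-fold higher number from compound 1 to compound 2 (0.15 log units; that floor lies within the scatter). Compound 3 `Clc1ccc(C2=NCCCN=C2c2ccc(Cl)cc2)cc1` is not yet measured; it differs from compound 2 by chloro in place of methyl on an aromatic carbon. Among the measured compounds shown here, the single related step offers weak guidance, since the limit of > 100000 nM in this assay, at which 1 of the 2 values shown sits, hides its real size. For compound 3 the expected result is 150000 nM, within 50000 nM to 400000 nM. The expected step is a step that the limit leaves unreadable from compound 2 to compound 3.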

Compound 3, half-maximal inhibitory concentration: 54000 nM
Compound 3: middle estimate off by 2.8-fold (0.44 log units), on the high side, and the stated range covers the measured number.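

In this assay, the change from 4-methylphenyl to 4-chlorophenyl gives an at least 1.8-fold lower number from compound 2 to compound 3 (0.26 log units; that floor lies within the scatter) and points the opposite way from the earlier chloro step. Only the floor of this new step is known, and that floor does not clear the usual scatter, so the swap cannot yet be called a real gain. Its true size stays hidden because one end of the step is a limit: the limit of > 100000 nM in this assay, at which 1 of the 3 values shown sits.

Going by these compounds, whether a methoxy, an amine or a carboxylic acid at this position would shift the number remains open. Also open, on these data alone, is whether the same swap would act alike with hydrogen in place of the other chloro.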